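A Cyclohexyl Swap on a Near-Complete Growth Inhibitor

A few compounds are considered here, and "the series" means these few. Any claim that something is new, unique, unknown or untested is made for them only; others in the source may bear on it.

Measured in a functional assay on MV4-11 cells (Homo sapiens) for inhibition, read by luminescence, with a stated time of 72 h, tested at 5 uM; a higher number here means more inhibition of growth at the concentration tested, a lower number less inhibition of growth:
- compound 1 `C=CS(=O)(=O)NC/C=C/c1cc(OC)cc(O)c1C(=O)OCC1CCCCC1`: 56.4%
- compound 2 `C=CS(=O)(=O)NC/C=C/c1cc(OC)cc(O)c1C(=O)OCC(C)c1ccccc1`: 9.6%
- compound 3 `COc1cc(O)c(C(=O)OCC(C)c2ccccc2)c(/C=C/CN2C(=O)C=CC2=O)c1`: 99%

Compound 3 stands highest of the three, beyond the scatter above both compound 1 and compound 2. The next compound, compound 4 `COc1cc(O)c(C(=O)OCC2CCCCC2)c(/C=C/CN2C(=O)C=CC2=O)c1`, has not yet been measured. It differs from compound 3 by one exchange: cyclohexyl in place of 1-phenylethyl on a saturated chain carbon bound to an oxygen next to a carbonyl group. In words, cyclohexyl takes the place of 1-phenylethyl on a saturated chain carbon bound to an oxygen next to a carbonyl group.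

The same exchange, read in the opposite direction, has been seen once, and the result was large: a number 46.8 percentage points lower from compound 1 to compound 2 (beyond the scatter). Cyclohexyl was thus the better of the two in that pair. The second measured step, a number 89.4 percentage points higher from compound 2 to compound 3 (beyond the scatter), is also large, and it is the change that compound 3 and compound 4 share. With that group in place, compound 3 already reaches 99%, leaving almost no room on this read-out for a rise. For the measured compounds named here, no measured pair shows what the exchange does at this level.

The estimate is a number 4 percentage points lower from compound 3 to compound 4 (within the scatter), a step expected to stay within the scatter. Compound 4 is expected at 95%, with an estimated range from 80% to 101%.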

Compound 4, percent growth inhibition at one concentration: 99.8%
Compound 4: the middle estimate sits 4.8 percentage points below what was measured, within the range that was stated.
By their numbers in this assay, from the lowest: compound 2; then compound 1; then compounds 3 and 4 (each within the scatter of the next).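

In this assay, the exchange on a saturated chain carbon bound to an oxygen next to a carbonyl group gives a number 0.8 percentage points higher from compound 3 to compound 4 (within the scatter), so cyclohexyl and 1-phenylethyl cannot be told apart once the five-membered ring group is present, although they were far apart with the open-chain sulfur group. The effect of this exchange therefore depends on the core that carries it: the same change on two cores in this assay, a number 46.8 percentage points lower (beyond the scatter) from compound 1 to compound 2 and a number 0.8 percentage points lower (within the scatter) from compound 4 to compound 3, 46 percentage points apart, beyond the scatter of two such steps The change of the group on the saturated chain carbon bound to a double-bonded chain carbon, read with cyclohexyl in place, gives a number 43.4 percentage points higher from compound 1 to compound 4 (beyond the scatter), which is large but differs clearly from the same change made with 1-phenylethyl in place: the same change on two cores in this assay, a number 89.4 percentage points higher (beyond the scatter) from compound 2 to compound 3 and a number 43.4 percentage points higher (beyond the scatter) from compound 1 to compound 4, 46 percentage points apart, beyond the scatter of two such steps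

Both compounds that carry the five-membered ring group lie close to the top of this read-out at the single concentration tested, so the compounds shown leave open whether cyclohexyl and 1-phenylethyl would separate at a lower concentration. They also leave open what an amine or a longer chain would do in place of cyclohexyl on the same carbon with this core.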